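A few compounds are considered here, and "the series" means these few. Any claim that something is new, unique, unknown or untested is made for them only; others in the source may bear on it.

For the measured compounds named here, compound 1 `COc1cc(CCc2ccc(Cl)c(Cl)c2)cc(OC)c1O` gives 20600 nM in a functional assay on MKN-45 cells (Homo sapiens) for antiproliferative activity, read by MTT assay, with a stated time of 72 h (a higher number here means a weaker inhibitor, a lower number a stronger inhibitor), and holds the only true number so far. Compound 2 `COc1cc(CCc2ccccc2F)cc(OC)c1O` is recorded only as a limit, > 25000 nM in the same test. Going by the values given here, the two compounds differ in more than one place, so they offer no measured step for a single change. The next case is compound 3 `COc1cc(CCc2ccc(Cl)cc2)cc(OC)c1O`, which keeps the core of compound 1. The change is hydrogen in place of chloro on an aromatic carbon, ortho to a chloro group. Among the compounds with values here, with no measured step to lean on, only a small shift is expected in this assay, towards weaker inhibition if it goes beyond the scatter at all. This expectation starts from compound 1 at 20600 nM as the sole numerical anchor. The expected size of the change is given by a 1.3-fold higher number from compound 1 to compound 3 (0.10 log units; within the scatter) and remains an estimate. For compound 3 the estimated value is 26000 nM, with an expected range from 13000 nM to 50000 nM in this estimate.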

Compound 3, half-maximal inhibitory concentration: > 25000 nM
Compound 3: only a limit was reported; the forecaster's own chance of this, stated with the estimate: 50%; the middle value does not contradict the limit.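

Taking away this chloro, ortho to a chloro group and meta to a large group, gives the first measured step for a single change among these compounds, an at least 1.2-fold higher number from compound 1 to compound 3 (0.08 log units; that floor lies within the scatter), and this is a floor and not a measured size. From the compounds shown here alone, the true size of the change therefore stays unknown, and the floor alone does not show a shift beyond the scatter. What the position adds is that, in this assay, compound 1 with both chloro groups holds a true number, whereas compound 3 with a single chloro is recorded only as a limit, and the data cannot separate it from the other compound at that limit: the limit of > 25000 nM in this assay, at which 2 of the 3 values shown sit.

The compounds shown leave open how far compound 3 actually lies from compound 1, and so how much this chloro contributes. They also leave open whether a bromo, methyl, methoxy or trifluoromethyl group or an amine in this place would give a true number in this assay, as the chloro of compound 1 does.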